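Nitro in Place of Cyano on Two Related Cores

The compounds below may be only part of what the source reports. "The series", "measured", "known", "first", "only" and "open" are said of these compounds alone.

Measured compounds:
compound 1 `CC(O)(CSc1ccc(S(F)(F)(F)(F)F)cc1)C(=O)Nc1ccc(C#N)cc1C(F)(F)F`: 15100 nM
compound 2 `CC(O)(CSc1ccc(S(F)(F)(F)(F)F)cc1)C(=O)Nc1ccc([N+](=O)[O-])cc1C(F)(F)F`: 10300 nM
compound 3 `CC(O)(COc1cccc(S(F)(F)(F)(F)F)c1)C(=O)Nc1ccc(C#N)cc1C(F)(F)F`: 9900 nM

In a functional assay on LNCaP cells (Homo sapiens) for antiproliferative activity, read by propidium iodide staining, with a stated time of 96 h (a lower number here means a stronger inhibitor, a higher number a weaker inhibitor), compound 1 gives 15100 nM, compound 2 gives 10300 nM and compound 3 gives 9900 nM. Compound 2 arises from compound 1 by nitro in place of cyano on an aromatic carbon, and this step is a 1.5-fold lower number from compound 1 to compound 2 (0.17 log units; within the scatter). The difference between the core of compound 1 and the core of compound 3 is not broken down here; their two values lie within the scatter of each other. Compound 4 `CC(O)(COc1cccc(S(F)(F)(F)(F)F)c1)C(=O)Nc1ccc([N+](=O)[O-])cc1C(F)(F)F` has not been measured; it arises from compound 3 by nitro in place of cyano on an aromatic carbon, the same change at the same place. In this assay the step from compound 3 to compound 4 is expected to be a 1.4-fold lower number from compound 3 to compound 4 (0.15 log units; within the scatter), resting on the step of a 1.5-fold lower number from compound 1 to compound 2 (0.17 log units; within the scatter). Compound 4 is therefore estimated at 7000 nM, expected between 3500 nM and 14000 nM.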

Compound 4, half-maximal inhibitory concentration: 12100 nM
For compound 4 the middle estimate is 1.7-fold (0.24 log units) below the measured one; measured number inside the range.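

In this assay, nitro in place of cyano on the core of compound 3 gives a 1.2-fold higher number from compound 3 to compound 4 (0.09 log units; within the scatter). Set beside the earlier step, the two cores do not separate: the same change on two cores in this assay, a 1.5-fold lower number (0.17 log units; within the scatter) from compound 1 to compound 2 and a 1.2-fold higher number (0.09 log units; within the scatter) from compound 3 to compound 4, 1.8-fold (0.25 log units) apart, within the scatter of two such steps. The change therefore carries from one core to the other without a gap that stands clear of the scatter, but neither step stands clear of it either, so the pair shows no real effect of the change on either core and cannot test whether a larger effect would carry across.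

Going by these compounds, it remains open whether an amine or a carboxylic acid on the same aromatic carbon would give a step beyond the scatter. On these data alone, the separate contributions of the differences between the core of compound 1 and the core of compound 3 also remain open.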